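This account rests on a few compounds, and the source may have more. Where it says the series, first, only, none or still open, it means among the compounds named here.

Three compounds measured in an assay on cells for antagonist activity at transient receptor potential cation channel subfamily V member 1 (Homo sapiens), read by FLIPR and calcium flux, with a stated time of 6 min (on this read-out higher numbers stand for weaker inhibition and lower numbers for stronger inhibition), share one amide scaffold and differ at a single aromatic carbon of the core. Compound 1 `CC(C(=O)NCc1ccc(C(C)(C)C)nc1OC1CCCC1)c1ccc(NS(C)(=O)=O)c(F)c1` gives 1.5 nM. Compound 2 `COc1ccc(CSc2nc(C(C)(C)C)ccc2CNC(=O)C(C)c2ccc(NS(C)(=O)=O)c(F)c2)cc1` gives 3.5 nM, which corresponds to a 2.3-fold higher number from compound 1 to compound 2 (0.37 log units; beyond the scatter). Compound 3 `CC1CCN(c2cc(C(C)(C)C)ccc2CNC(=O)C(C)c2ccc(NS(C)(=O)=O)c(F)c2)CC1` gives 0.7 nM, the lowest of the three numbers, with compound 1 nearest and compound 2 furthest. Compound 4 `CC(C(=O)NCc1ccc(C(C)(C)C)cc1OC1CCCC1)c1ccc(NS(C)(=O)=O)c(F)c1` is the next candidate, and it differs from compound 3 by cyclopentyloxy in place of 4-methylpiperidin-1-yl on an aromatic carbon. Within the data shown here, no measured step exchanges these two groups directly, so the change has no precedent here; the single step at this position, from compound 1 to compound 2, swaps other groups and was modest. Compound 1 carries the same cyclopentyloxy group on a closely related core and stands somewhat above compound 3. For compound 4 the expected step is therefore a 1.7-fold higher number from compound 3 to compound 4 (0.23 log units; within the scatter), a small move upward that may not clear the scatter. The estimate for compound 4 is 1.2 nM, with a range from 0.5 nM to 3 nM.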

Compound 4, inhibition constant: 1.8 nM
For compound 4 the middle estimate is 1.5-fold (0.18 log units) below the measured one; measured number inside the range.
By their numbers in this assay, from the lowest: compound 3; then compounds 1, 4 and 2 (each within the scatter of the next, the first and the last beyond it).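

In this assay, the exchange at this aromatic carbon now has a direct reading, with cyclopentyloxy in place of 4-methylpiperidin-1-yl giving a 2.6-fold higher number from compound 3 to compound 4 (0.41 log units; beyond the scatter). The position therefore distinguishes between these two ring-bearing groups, although the step remains modest. With cyclopentyloxy on both cores, compound 1 at 1.5 nM and compound 4 at 1.8 nM lie within the scatter of each other, so this pair shows no clear effect of the core difference with this group.

Nothing available here explains the step between the two groups. From the compounds shown here alone, it remains open whether an open-chain amine such as dimethylamino, a smaller ether such as methoxy or a longer chain such as n-butoxy at this carbon would stay close to these values.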